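Phenyl for Ethynyl on the Pyridine Ether of Compound 2

A few compounds are considered here, and "the series" means these few. Any claim that something is new, unique, unknown or untested is made for them only; others in the source may bear on it.

The measured compounds, in a functional assay on CHO-K1 cells for antagonist activity at Orexin/Hypocretin receptor type 1 (Homo sapiens), read by FLIPR and calcium flux; on this read-out lower numbers stand for stronger inhibition and higher numbers for weaker inhibition:
compound 1 `CCOC(=O)c1ccccc1C(=O)N1C[C@H](Oc2cc(C#N)ccn2)CC[C@H]1C`, compound 1 gives 7100 nM
compound 2 `C#Cc1ccnc(O[C@@H]2CC[C@@H](C)N(C(=O)c3ccccc3-n3nccn3)C2)c1`, compound 2 gives 240 nM
compound 3 `Cc1cccc(O[C@@H]2CC[C@@H](C)N(C(=O)c3ccccc3-n3nccn3)C2)n1`, compound 3 gives 745 nM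

Compound 2 has the lowest number of the three. Its nearest neighbour is compound 3, reached by the step of a 3.1-fold higher number from compound 2 to compound 3 (0.49 log units; beyond the scatter), and compound 1 lies much further, its number being far higher than that of compound 2.

Compound 4 `C[C@@H]1CC[C@@H](Oc2cc(-c3ccccc3)ccn2)CN1C(=O)c1ccccc1-n1nccn1` is not yet measured. It differs from compound 2 by one change: phenyl in place of ethynyl on an aromatic carbon.

Going by the values given here, no measured pair shows this change. Among the compounds with values here, the only step among the three compounds, the one from compound 2 to compound 3, concerns another group at another place on the same pyridine ring, and so tells nothing direct about a phenyl entering for an ethynyl. What is left is that the substituted pyridine ether of compound 2 carries the best number here, and that a larger carbon-only ring at the same carbon is not contradicted by any measured value.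

Compound 4 is therefore expected to stay close to compound 2, with the step of a 1.2-fold lower number from compound 2 to compound 4 (0.08 log units; within the scatter), giving an estimate of 200 nM, within a range from 50 nM to 800 nM.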

Compound 4, half-maximal inhibitory concentration: 2400 nM
Beside the measured number, compound 4's estimate is 12-fold (1.08 log units) below it, outside the stated range (above it).
By their numbers in this assay, from the lowest: compound 2; then compound 3; then compound 4; then compound 1.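

In this assay, putting phenyl in place of ethynyl gives a 10-fold higher number from compound 2 to compound 4 (1.00 log units; beyond the scatter), so the aromatic carbon opposite the ring nitrogen does not accept every carbon-only group equally, and a six-membered aromatic ring there gives up much of the standing of compound 2. Going by these compounds alone, this is the first measured change at this carbon, since the earlier step, a 3.1-fold higher number from compound 2 to compound 3 (0.49 log units; beyond the scatter), exchanged the 4-ethynylpyridin-2-yl group for a 6-methylpyridin-2-yl group and so could not separate what this carbon alone contributes. Nothing measured alongside these numbers accounts for the loss, so the step stands here as an observation without an explanation.

The compounds shown leave open whether the loss follows the larger count of heavy atoms or the aromatic ring itself, as one step cannot separate the two. A cyclopropyl ring or an amine on the same carbon would bear on that question, and on whether any group at this carbon can give a number lower than that of compound 2, which for now rests on ethynyl alone.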